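This account rests on a few compounds, and the source may have more. Where it says the series, first, only, none or still open, it means among the compounds named here.

Of the compounds shown here, three have so far been measured in a functional assay on SH-SY5Y cells (Homo sapiens) for cytotoxicity, read by MTT assay, with a stated time of 48 h; on this read-out higher numbers stand for weaker inhibition and lower numbers for stronger inhibition. Compound 1, `COc1cc(/C=C/C(=O)/C=C/c2nc3cc(C)ccc3n2C)ccc1O`, gives 4700 nM in this assay. Compound 2, `COc1cc(/C=C/C(=O)/C=C/c2nc3c(C)c(C)ccc3n2C)ccc1O`, gives 19000 nM in this assay. Compound 3, `COc1ccc(/C=C/C(=O)/C=C/c2nc3ccccc3n2C)cc1O`, gives 4800 nM in this assay, a number that lies within the usual scatter of that of compound 1. How the core of compound 3 differs from the core of compound 1 is not broken down here.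

Between compound 1 and compound 2 the change is methyl in place of hydrogen on an aromatic carbon. This step made a 4.0-fold higher number from compound 1 to compound 2 (0.61 log units; beyond the scatter), so the added methyl weakened inhibition.

Compound 4, `COc1ccc(/C=C/C(=O)/C=C/c2nc3cc(C)ccc3n2C)cc1O`, has not yet been measured. It arises from compound 3 by methyl in place of hydrogen on an aromatic carbon. Within the data shown here, this is the same kind of change as the one from compound 1 to compound 2, but not the same: in compound 2 the entering methyl sits ortho to a fused ring and ortho to a methyl group, whereas in compound 4 it sits meta to a fused ring and para to a fused ring, with no methyl group named around it.

Among the measured compounds shown here, the one measured step of this kind weakened inhibition, but at a different place, and compound 1, which already carries such a methyl, sits within the scatter of compound 3, which does not. A small step is therefore expected, estimated as a 1.4-fold higher number from compound 3 to compound 4 (0.13 log units; within the scatter). This expectation rests on a 4.0-fold higher number from compound 1 to compound 2 (0.61 log units; beyond the scatter), and on the fact that compound 1 gives 4700 nM while compound 3 gives 4800 nM. Compound 4 is expected to give about 6500 nM in this assay, estimated to fall between 2500 nM and 17000 nM.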

Compound 4, half-maximal inhibitory concentration: 4800 nM
Beside the measured number, compound 4's estimate is 1.4-fold (0.13 log units) above it; the measured number falls inside the stated range.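

In this assay, putting a methyl in place of a hydrogen on an aromatic carbon gave no change at the digits printed from compound 3 to compound 4 (within the scatter), whereas the same kind of change had earlier given a 4.0-fold higher number from compound 1 to compound 2 (0.61 log units; beyond the scatter). The size of this change therefore cannot simply be carried from one core to another in this series, as the two steps disagree: the same change on two cores in this assay, a 4.0-fold higher number (0.61 log units; beyond the scatter) from compound 1 to compound 2 and no change at the digits printed (within the scatter) from compound 3 to compound 4, 4.0-fold (0.61 log units) apart, beyond the scatter of two such steps. These two steps do not show why they differ, since the methyl enters at a different place in each case and the two starting compounds also differ elsewhere, so the place of the methyl and the rest of the molecule cannot be told apart, and two steps alone give no general rule.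

The compounds shown leave open how a methyl entering at the place it takes in compound 2 would behave on the core of compound 3, which would help separate those two explanations. They also leave open what other groups would do on this ring in place of methyl, such as a longer chain like ethyl, a chlorine atom or an amine.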